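This account rests on a few compounds, and the source may have more. Where it says the series, first, only, none or still open, it means among the compounds named here.

Measured compounds:
compound 1 `CC(C)(C)OC(=O)N1CCCN(CCCCCOc2c(Br)cc(Br)cc2Oc2ccc(Br)cc2Br)CC1`: 39.5 ug/mL
compound 2 `Brc1ccc(Oc2cc(Br)cc(Br)c2OCCCCCN2CCN(C/C=C/c3ccccc3)CC2)c(Br)c1`: 32.7 ug/mL
compound 3 `COc1c(Br)cc(Br)cc1Oc1ccc(Br)cc1Br`: 34.5 ug/mL

In a functional assay on U-937 cells (Homo sapiens) for cytotoxicity, read by MTT assay, with a stated time of 24 h (a higher number here means a weaker inhibitor, a lower number a stronger inhibitor), the three measured compounds all give numbers close together. Compound 3 stands second highest of the three, and its distance to compound 2 and to compound 1 lies within the scatter, so no order among them can be read.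

Compound 4 `BrCCCCCCOc1c(Br)cc(Br)cc1Oc1ccc(Br)cc1Br` follows from compound 3 by one change: 5-bromopentyl in place of hydrogen on a saturated chain carbon bound to an oxygen on an aromatic ring. Among the measured compounds shown here, no measured pair shows this change, so its effect is unknown. Since compounds 1 and 2 carry long chains on the same oxygen and yet give values near compound 3, the step from compound 3 to compound 4 is expected to be a 1.0-fold lower number from compound 3 to compound 4 (0.02 log units; within the scatter), nothing beyond the scatter in either direction. Compound 4 is therefore estimated at 33 ug/mL, expected between 15 ug/mL and 70 ug/mL.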

Compound 4, half-maximal inhibitory concentration: 33.8 ug/mL
The estimate for compound 4 lay 1.0-fold (0.01 log units) below the measured number; the measured number falls inside the stated range.
By their numbers in this assay, from the lowest: compounds 2, 4, 3 and 1 (each within the scatter of the next).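

Putting 5-bromopentyl in place of hydrogen on a saturated chain carbon bound to an oxygen on an aromatic ring gives, in this assay, a 1.0-fold lower number from compound 3 to compound 4 (0.01 log units; within the scatter). Among the compounds shown here, this is the first pair here that differs in one place, and it shows that this chain, carrying its bromine, does not shift the number beyond the scatter at this position. Nothing available speaks to the reason for this. As far as these compounds go, it remains open whether a carboxylic acid or a longer chain in place of 5-bromopentyl would move the number beyond the scatter from compound 3.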